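A few compounds are considered here, and "the series" means these few. Any claim that something is new, unique, unknown or untested is made for them only; others in the source may bear on it.

Measured so far in an ADME assay on L1210 cells (Mus musculus) for cytotoxicity, read by cell counting, with a stated time of 2 days; on this read-out lower numbers stand for stronger inhibition and higher numbers for weaker inhibition: compound 1 `CC(C)(C)c1ccc(-n2cc(-c3cn([C@H]4C[C@H](O)[C@@H](CO)O4)c(=O)[nH]c3=O)nn2)cc1` gives 15000 nM; compound 2 `CCCCc1ccc(-n2cc(-c3cn([C@H]4C[C@H](O)[C@@H](CO)O4)c(=O)[nH]c3=O)nn2)cc1` gives 15000 nM; compound 3 `O=c1[nH]c(=O)n([C@H]2C[C@H](O)[C@@H](CO)O2)cc1-c1cn(-c2ccc(OC(F)(F)F)cc2)nn1` gives 50000 nM.

All three share one core and differ only in the group carried on an aromatic carbon at the far end of the molecule. Compound 3 stands at the highest number of the three, that is, it is the weakest inhibitor of the set: a 3.3-fold higher number from compound 1 to compound 3 (0.52 log units; beyond the scatter) and a 3.3-fold higher number from compound 2 to compound 3 (0.52 log units; beyond the scatter), whereas no change at the digits printed from compound 1 to compound 2 (within the scatter).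

Compound 4 `O=c1[nH]c(=O)n([C@H]2C[C@H](O)[C@@H](CO)O2)cc1-c1cn(-c2ccc(Oc3ccccc3)cc2)nn1` has not yet been measured in this assay. It differs from compound 3 by phenyl in place of trifluoromethyl on an oxygen on an aromatic ring. Going by the values given here, no measured step alters a group on that oxygen, so the only guide is that the two swaps of the whole group on the aromatic carbon moved the number modestly, as seen in a 3.3-fold higher number from compound 1 to compound 3 (0.52 log units; beyond the scatter) and a 3.3-fold higher number from compound 2 to compound 3 (0.52 log units; beyond the scatter). A change of similar size is therefore expected, and the direction is uncertain; a slight lean toward a lower number seems fair because a 3.3-fold higher number from compound 2 to compound 3 (0.52 log units; beyond the scatter) shows that the trifluoromethoxy variant sits at the top of this set. For compound 4 in this assay the estimate is 30000 nM, with a range from 10000 nM to 100000 nM, meaning an expected step of a 1.7-fold lower number from compound 3 to compound 4 (0.22 log units; within the scatter).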

Compound 4, half-maximal inhibitory concentration: 500 nM
Compound 4: the middle estimate sits 60-fold (1.78 log units) above what was measured, outside the stated range (below it).
By their numbers in this assay, from the lowest: compound 4; then compounds 1 and 2 (each within the scatter of the next); then compound 3.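

In this assay, the group on an oxygen on an aromatic ring proves able to move the number far more than the earlier swaps suggested: phenyl in place of trifluoromethyl gives a 100-fold lower number from compound 3 to compound 4 (2.00 log units; beyond the scatter), whereas replacing the whole group on the aromatic carbon had earlier given only a 3.3-fold higher number from compound 1 to compound 3 (0.52 log units; beyond the scatter). Phenoxy also stands well apart from both carbon-linked groups, with a 30-fold lower number from compound 2 to compound 4 (1.48 log units; beyond the scatter) for the change from butyl and a 30-fold lower number from compound 1 to compound 4 (1.48 log units; beyond the scatter) for the change from tert-butyl, which makes compound 4 the strongest inhibitor of these four in this cell-killing read-out. No measurement shown here explains why swapping trifluoromethyl for phenyl has so large an effect.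

The compounds shown leave open whether the size of this step depends on the phenyl ring alone or on the oxygen that joins it to the rest of the molecule, a question that a benzyloxy group or a phenyl group on the same aromatic carbon could help to settle. They also leave open how the number would respond to an amine or a carboxylic acid on the new phenyl ring.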